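Compound 3 to compound 4: hydroxy in place of fluoro

This account rests on a few compounds, and the source may have more. Where it says the series, first, only, none or still open, it means among the compounds named here.

In a functional assay on MDA-MB-231 cells (Homo sapiens) for antiproliferative activity, read by MTT assay, with a stated time of 48 h (a lower number here means a stronger inhibitor, a higher number a weaker inhibitor), compound 1 `C/C(=C\CC/C(C)=C/CC[C@@H]1[C@@]2(C)CCC(=O)C(C)(C)[C@H]2CC[C@@]1(C)O)CC/C=C(\C)C(=O)OCc1cn(-c2ccc(C(F)(F)F)cc2)nn1` reaches only a limit, > 150000 nM. Compound 2 `C#CCOC(=O)/C(C)=C/CC/C(C)=C/CC/C(C)=C/CC[C@@H]1[C@@]2(C)CCC(=O)C(C)(C)[C@H]2CC[C@@]1(C)O` gives 114000 nM. Compound 3 `C/C(=C\CC/C(C)=C/CC[C@@H]1[C@@]2(C)CCC(=O)C(C)(C)[C@H]2CC[C@@]1(C)O)CC/C=C(\C)C(=O)OCc1cn(-c2cccc(F)c2)nn1` gives 144000 nM, which stands level with compound 2 within the scatter. Both steps that reach compound 3 are small: an at least 1.0-fold lower number from compound 1 to compound 3 (0.01 log units; that floor lies within the scatter), and a 1.3-fold higher number from compound 2 to compound 3 (0.10 log units; within the scatter).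

Compound 4 `C/C(=C\CC/C(C)=C/CC[C@@H]1[C@@]2(C)CCC(=O)C(C)(C)[C@H]2CC[C@@]1(C)O)CC/C=C(\C)C(=O)OCc1cn(-c2cccc(O)c2)nn1` carries hydroxy in place of fluoro on an aromatic carbon, meta to a large group. Among the measured compounds shown here, no measured step tests this exchange directly. The closest is the change of the group on the aromatic nitrogen, an at least 1.0-fold lower number from compound 1 to compound 3 (0.01 log units; that floor lies within the scatter), which stays within the scatter, as does the replacement of ethynyl in a 1.3-fold higher number from compound 2 to compound 3 (0.10 log units; within the scatter). On that basis, no change beyond the scatter is expected in this assay, and the expected step is a 1.3-fold lower number from compound 3 to compound 4 (0.12 log units; within the scatter). For compound 4 the estimated value is 110000 nM, with an expected range from 55000 nM to 150000 nM.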

Compound 4, half-maximal inhibitory concentration: 139000 nM
Beside the measured number, compound 4's estimate is 1.3-fold (0.10 log units) below it, and the stated range covers the measured number.
By their numbers in this assay, from the lowest: compounds 2, 4 and 3 (each within the scatter of the next). At a limit, above all of these: compound 1.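

In this assay, among the compounds shown here, fluoro and hydroxy on this aromatic carbon are directly compared for the first time, and the exchange, which brings one hydrogen-bond donor and one acceptor, stays within the scatter (a 1.0-fold lower number from compound 3 to compound 4 (0.02 log units; within the scatter)). The 1-(3-hydroxyphenyl)-1H-1,2,3-triazol-4-yl group in place of ethynyl also stays within the scatter (a 1.2-fold higher number from compound 2 to compound 4 (0.09 log units; within the scatter)), as its 3-fluorophenyl counterpart did. Compound 1 gives only a limit, so the comparison with it yields only a floor (an at least 1.0-fold lower number from compound 1 to compound 4 (0.03 log units; that floor lies within the scatter)) and says little about the true size of that step: the limit of > 150000 nM in this assay, at which 1 of the 4 values shown sits.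

Going by these compounds, whether any group on this aromatic carbon can move the number beyond the scatter remains open. An amine or a carboxylic acid here would test that, and a replacement for the ester linking the chain to the triazole is equally untested in the compounds shown.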